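A few compounds are considered here, and "the series" means these few. Any claim that something is new, unique, unknown or untested is made for them only; others in the source may bear on it.

Of the compounds shown here, two built on the same core have been measured in a functional assay on SNU-638 cells (Homo sapiens) for cytotoxicity, read by sulforhodamine B assay, with a stated time of 72 h; a higher number here means a weaker inhibitor, a lower number a stronger inhibitor. Compound 1 `CCS(=O)(=O)Nc1cc(-c2ccc3ncnc(Nc4ccc(OC)c(OC)c4)c3c2)cnc1OC` gives 1680 nM in this assay. Among the compounds with values here, compound 2 `CCS(=O)(=O)Nc1cc(-c2ccc3ncnc(Nc4ccc(OC)c(Cl)c4)c3c2)cnc1OC` gives 3620 nM, the higher of the two numbers; the single step that joins them, a 2.2-fold higher number from compound 1 to compound 2 (0.33 log units; beyond the scatter), exchanges one group for another on the ring that sits on a nitrogen on an aromatic ring. Compound 3 `CCS(=O)(=O)Nc1cc(-c2ccc3ncnc(Nc4ccc(F)c(C(=O)OC)c4)c3c2)cnc1OC` has not yet been measured. It differs from compound 2 by 4-fluoro-3-(methoxycarbonyl)phenyl in place of 3-chloro-4-methoxyphenyl on a nitrogen on an aromatic ring. Within the data shown here, no measured step covers this exchange: the step from compound 1 to compound 2 touched the same ring but traded one group for another, whereas in compound 3 both groups on that ring are replaced at once. Among the measured compounds shown here, the one known step was modest and beyond the scatter, so a change of that order in either direction is plausible, and nothing in the data favours one direction. Compound 3 is therefore expected to land near compound 2, with a wide range: the estimate is 3500 nM (from 1200 nM to 12000 nM), which corresponds to an expected step of a 1.0-fold lower number from compound 2 to compound 3 (0.01 log units; within the scatter).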

Compound 3, half-maximal inhibitory concentration: 2540 nM
The estimate for compound 3 lay 1.4-fold (0.14 log units) above the measured number; the range from low to high includes it.
By their numbers in this assay, from the lowest: compounds 1, 3 and 2 (each within the scatter of the next, the first and the last beyond it).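

In this assay, putting 4-fluoro-3-(methoxycarbonyl)phenyl in place of 3-chloro-4-methoxyphenyl on a nitrogen on an aromatic ring gives a 1.4-fold lower number from compound 2 to compound 3 (0.15 log units; within the scatter), and putting the same group in place of 3,4-dimethoxyphenyl gives a 1.5-fold higher number from compound 1 to compound 3 (0.18 log units; within the scatter). The earlier compounds shown here showed only that trading chloro for methoxy on this ring gave a step beyond the scatter, whereas compound 3 shows that replacing both groups at once, with a fluoro and a methoxycarbonyl group, gives a step beyond the scatter from neither compound 1 nor compound 2. No accompanying measurement bears on this result.

The compounds shown leave open what the fluoro and the methoxycarbonyl group each contribute alone, since they enter together and their separate steps cannot be read. Going by these compounds, it also remains open whether a carboxylic acid or a primary amide in place of the methoxycarbonyl group, or an amine on the same ring, would move the number in this assay beyond the scatter, and how any change away from this ring would read.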